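Swapping a Nitro for a Propyl on the Amide Ring

This account rests on a few compounds, and the source may have more. Where it says the series, first, only, none or still open, it means among the compounds named here.

Three measured compounds share one core and differ only in the ring that sits on the amide carbonyl. In a functional assay on MDA-MB-231 cells (Homo sapiens) for antiproliferative activity, read by CCK-8 assay, with a stated time of 72 h (a higher number here means a weaker inhibitor, a lower number a stronger inhibitor), compound 1 `COc1cccc(C(=O)Nc2cccc(-c3oc4cc(-c5ccc(F)cc5)ccc4c(=O)c3O)c2)c1` gives 9160 nM. Compound 2 `O=C(Nc1cccc(-c2oc3cc(-c4ccc(F)cc4)ccc3c(=O)c2O)c1)c1cccc(F)c1` gives 2510 nM in this assay, and compound 3 `O=C(Nc1cccc(-c2oc3cc(-c4ccc(F)cc4)ccc3c(=O)c2O)c1)c1ccc([N+](=O)[O-])cc1` gives 14700 nM. Among these numbers the one step beyond the scatter is a 5.9-fold higher number from compound 2 to compound 3 (0.77 log units; beyond the scatter); the other, a 1.6-fold higher number from compound 1 to compound 3 (0.21 log units; within the scatter), stays within it, so compound 3 is clearly separated from compound 2 only.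

Compound 4 `CCCc1ccc(C(=O)Nc2cccc(-c3oc4cc(-c5ccc(F)cc5)ccc4c(=O)c3O)c2)cc1` has not been measured. It differs from compound 3 by propyl in place of nitro on an aromatic carbon. Among the compounds with values here, no measured step exchanges exactly these two groups; what bears on the change is that both steps ending at the nitro-bearing ring, a 1.6-fold higher number from compound 1 to compound 3 (0.21 log units; within the scatter) and a 5.9-fold higher number from compound 2 to compound 3 (0.77 log units; beyond the scatter), run upward or flat, never downward. Leaving the nitro behind is therefore expected to give a lower number, of modest size at most, with wide uncertainty. Compound 4 is expected to give 6000 nM in this assay, within 2000 nM to 18000 nM, an expected step of a 2.5-fold lower number from compound 3 to compound 4 (0.39 log units; beyond the scatter).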

Compound 4, half-maximal inhibitory concentration: 32200 nM
The estimate for compound 4 lay 5.4-fold (0.73 log units) below the measured number; the measured number lies above the stated range.
By their numbers in this assay, from the lowest: compound 2; then compounds 1 and 3 (each within the scatter of the next); then compound 4.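

In this assay the nitro turns out not to be the group that costs most at this aromatic carbon, since propyl gives a still higher number (a 2.2-fold higher number from compound 3 to compound 4 (0.34 log units; beyond the scatter)). Compound 4 also stands clearly above the two other rings (a 3.5-fold higher number from compound 1 to compound 4 (0.55 log units; beyond the scatter); a 13-fold higher number from compound 2 to compound 4 (1.11 log units; beyond the scatter)), the second being the largest step in the series and leaving compound 4 the weakest of the four. Nothing measured here accounts for this order.

The 4-nitrophenyl and 4-propylphenyl rings differ from the 3-methoxyphenyl and 3-fluorophenyl rings in both the group and its place, so these compounds cannot separate the two. On these data alone, how an amine, a methyl group or a longer chain on the same aromatic carbon would compare also stays open.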